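A few compounds are considered here, and "the series" means these few. Any claim that something is new, unique, unknown or untested is made for them only; others in the source may bear on it.

Measured so far:
- compound 1 `CCCCC(=O)N(Cc1ccc(OC)c(O)c1)c1cc(OC)c(OC)c(OC)c1`: 170 nM
- compound 2 `C/C=C/C(=O)N(Cc1ccc(OC)c(C)c1)c1cc(OC)c(OC)c(OC)c1`: 23500 nM

In a functional assay on HCT-116 cells (Homo sapiens) for inhibition, read by MTT assay, with a stated time of 48 h (on this read-out lower numbers stand for stronger inhibition and higher numbers for weaker inhibition), compound 1 gives 170 nM, the lowest of the two numbers; compound 2 gives 23500 nM, a gap beyond the scatter. Within the data shown here, the two differ in several places, so no single step is drawn between them.

Compound 3 `COc1ccc(CN(C(=O)CCl)c2cc(OC)c(OC)c(OC)c2)cc1O` is not yet measured. It differs from compound 1 by chloro in place of propyl on a saturated chain carbon bound to a carbonyl carbon, a change on a saturated chain carbon bound to a carbonyl carbon. Among the measured compounds shown here, no measured pair covers this change, so the step in this assay is expected to be small, within the scatter, with no clear direction. Compound 3 is therefore estimated at 150 nM (range 35 nM to 650 nM), an expected step of a 1.1-fold lower number from compound 1 to compound 3 (0.05 log units; within the scatter).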

Compound 3, half-maximal inhibitory concentration: 250 nM
Compound 3: middle estimate off by 1.7-fold (0.22 log units), on the low side; the measured number falls inside the stated range.
By their numbers in this assay, from the lowest: compounds 1 and 3 (each within the scatter of the next); then compound 2.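

At this position, on a saturated chain carbon bound to a carbonyl carbon, chloro in place of propyl gives in this assay a 1.5-fold higher number from compound 1 to compound 3 (0.17 log units; within the scatter). The acyl part of the core thus accepts this exchange: butyl and chloromethyl, the same difference cut one bond further out, give numbers within the scatter of each other. Nothing available bears on a cause for this result. Still open, from the compounds shown here alone, is how an amine, a carboxylic acid or a longer chain at this place would read out in this assay.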